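The source may report more compounds than this note shows. Statements on the series, on what has been measured and on what is new or still open speak of the compounds shown alone.

Of the compounds shown here, three sharing one core have been tested in an ADME assay on Huh-7 cells (Homo sapiens) for cytotoxicity, with a stated time of 72 h (on this read-out lower numbers stand for higher toxicity in this test and higher numbers for lower toxicity in this test), and they differ in the group on one aromatic carbon. Compound 1 `CC(C)CCn1nc(C2CCCCC2)c(O)c(C2=NS(=O)(=O)c3cc(NS(C)(=O)=O)ccc3N2)c1=O` carries cyclohexyl, compound 2 `CC(C)CCn1nc(CC2CCC2)c(O)c(C2=NS(=O)(=O)c3cc(NS(C)(=O)=O)ccc3N2)c1=O` carries cyclobutylmethyl and compound 3 `CC(C)CCn1nc(C2=CCCC2)c(O)c(C2=NS(=O)(=O)c3cc(NS(C)(=O)=O)ccc3N2)c1=O` carries cyclopent-1-en-1-yl. Compound 1 gives > 1000 nM, which is a limit. Compound 2 gives > 33000 nM, which is also a limit. Compound 3 gives > 1000 nM, again a limit, so it has no number of its own.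

Compound 4 `CC(C)CCc1nn(CCC(C)C)c(=O)c(C2=NS(=O)(=O)c3cc(NS(C)(=O)=O)ccc3N2)c1O` has isopentyl in place of cyclopent-1-en-1-yl on an aromatic carbon. Three measured steps change this same carbon: a step that the two limits leave unreadable from compound 1 to compound 2, a step that the two limits leave unreadable from compound 1 to compound 3 and a step that the two limits leave unreadable from compound 2 to compound 3. None has a readable size, so none can be carried over directly.

The expectation therefore leans on compound 2 at > 33000 nM, the highest limit seen. In this assay the expected step is a step that the limit leaves unreadable from compound 3 to compound 4, towards lower toxicity in this test, though this estimate starts from a limit. Compound 4 is expected at 30000 nM, with an estimated range of 5000 nM to 100000 nM.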

Compound 4, half-maximal cytotoxic concentration: > 33000 nM
Compound 4 ended at the assay's limit; the forecaster's own chance of this, stated with the estimate: 85%; middle value at least 1.1-fold (0.04 log units) away from the limit.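

In this assay compound 4 gives > 33000 nM, which is a limit. Its steps from compound 1, compound 2 and compound 3 all join two limits and cannot be read. The compounds shown leave open whether isopentyl on this aromatic carbon changes the read-out in this assay at all.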